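Swapping the biaryl ring: from chlorophenyl to dimethoxyphenyl

This account rests on a few compounds, and the source may have more. Where it says the series, first, only, none or still open, it means among the compounds named here.

Measured compounds:
compound 1 `COC(=O)/C=C/c1cccc(N(Cc2ccc(/C=C/c3ccc(F)cc3)cc2)C(=O)C(C)C)c1`: 120 nM
compound 2 `COC(=O)/C=C/c1cccc(N(Cc2ccc(/C=C/c3scnc3C)cc2)C(=O)C(C)C)c1`: 228 nM
compound 3 `COC(=O)/C=C/c1cccc(N(Cc2ccc(-c3cccc(Cl)c3)cc2)C(=O)C(C)C)c1`: 77 nM

In an assay on isolated protein with Bile acid receptor (Homo sapiens) as the target (on this read-out lower numbers stand for an effect already at smaller amounts and higher numbers for an effect only at larger amounts of compound), compound 3 stands at the smallest of the three numbers; the gap to compound 1 is within the scatter, a 3.0-fold lower number from compound 2 to compound 3 (0.47 log units; beyond the scatter) is beyond it. Compound 4 `COC(=O)/C=C/c1cccc(N(Cc2ccc(-c3c(OC)cccc3OC)cc2)C(=O)C(C)C)c1` differs from compound 3 in one place: 2,6-dimethoxyphenyl in place of 3-chlorophenyl on an aromatic carbon. Among the compounds with values here, no measured step changes this ring alone; a 1.6-fold lower number from compound 1 to compound 3 (0.19 log units; within the scatter) and a 3.0-fold lower number from compound 2 to compound 3 (0.47 log units; beyond the scatter) only show that the attached ring tolerates exchange for a double-bonded chain without large shifts. For compound 4 the step of a 1.9-fold higher number from compound 3 to compound 4 (0.29 log units; within the scatter) is therefore expected to be small, with no firm direction. Compound 4 is estimated at 150 nM in this assay, with a range from 50 nM to 500 nM.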

Compound 4, half-maximal effective concentration: 95 nM
For compound 4 the middle estimate is 1.6-fold (0.20 log units) above the measured one; the range from low to high includes it.
By their numbers in this assay, from the lowest: compounds 3, 4, 1 and 2 (each within the scatter of the next, the first and the last beyond it).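

In this assay, 2,6-dimethoxyphenyl can replace 3-chlorophenyl at this aromatic carbon with a 1.2-fold higher number from compound 3 to compound 4 (0.09 log units; within the scatter), so a ring carrying two hydrogen-bond acceptors is accepted here as well as one carrying chlorine. Compared with the ethenyl-linked rings, the same group gives a 1.3-fold lower number from compound 1 to compound 4 (0.10 log units; within the scatter) against 2-(4-fluorophenyl)ethenyl and a 2.4-fold lower number from compound 2 to compound 4 (0.38 log units; beyond the scatter) against 2-(4-methyl-1,3-thiazol-5-yl)ethenyl. No supporting data explain these results. On these data alone, whether this ring would also accept an amine or a carboxylic acid remains open.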